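A few compounds are considered here, and "the series" means these few. Any claim that something is new, unique, unknown or untested is made for them only; others in the source may bear on it.

Measured so far in an ADME assay on microsomes from liver (Rattus norvegicus) for metabolic stability; on this read-out higher numbers stand for a longer-lived compound and lower numbers for a shorter-lived compound:
- compound 1, `CC(C)C(Nc1nnc[nH]1)c1ccc(-c2ccc3cccc(F)c3c2)[nH]c1=O`: 1.29 h
- compound 2, `CC(C)C(c1ncc[nH]1)c1ccc(-c2ccc3cccc(F)c3c2)[nH]c1=O`: a limit, < 0.0667 h
- compound 3, `CC(C)C(c1noc(=O)[nH]1)c1ccc(-c2ccc3cccc(F)c3c2)[nH]c1=O`: a limit, > 3 h

Going by the values given here, compound 1 is the only member of the set with a number in this assay; for compound 2 the value is a limit of the assay, and for compound 3 the value is likewise a limit (the limit of < 0.0667 h in this assay, at which 1 of the 3 values shown sits, (the limit of > 3 h in this assay, at which 1 of the 3 values shown sits)). Compound 4, `CC(C)NC(=O)CC(c1ccc(-c2ccc3cccc(F)c3c2)[nH]c1=O)C(C)C`, has not yet been measured.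

The step from compound 1 to compound 4 is (isopropylcarbamoyl)methyl in place of (4H-1,2,4-triazol-3-yl)amino on a saturated chain carbon bound to an aromatic carbon and a saturated chain carbon. The two measured steps from compound 1 change the same position and point in opposite directions: an at least 19-fold lower number from compound 1 to compound 2 (1.28 log units; beyond the scatter), while an at least 2.3-fold higher number from compound 1 to compound 3 (0.36 log units; beyond the scatter). Between compounds 2 and 3 the gap is an at least 44-fold higher number from compound 2 to compound 3 (1.65 log units; beyond the scatter). Both measured steps swap one five-membered aromatic ring for another; the change to compound 4 instead brings in a group with no ring, so neither step transfers directly. The measured spread shows that this position can move the read-out by a large amount either way, and no direction is favoured by the data.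

Compound 4 is therefore expected to give about 1 h in this assay, with an estimated range from 0.25 h to 3 h, which means an expected step of a 1.3-fold lower number from compound 1 to compound 4 (0.11 log units; within the scatter).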

Compound 4, half-life: < 0.0667 h
Compound 4 gave a limit, no number; the forecaster's own chance of this, stated with the estimate: 30%; middle value at least 14-fold (1.17 log units) away from the limit.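

In this assay the value of compound 4 is a limit and not a number: the limit of < 0.0667 h in this assay, at which 2 of the 4 values shown sit.

Going by these compounds alone, the (isopropylcarbamoyl)methyl group, the first group with no ring at this saturated chain carbon, gives an at least 19-fold lower number from compound 1 to compound 4 (1.28 log units; beyond the scatter) and an at least 44-fold lower number from compound 3 to compound 4 (1.65 log units; beyond the scatter). The short-lived end of the series at this position is therefore no longer tied to a five-membered aromatic ring: it now holds both compound 2, with 1H-imidazol-2-yl, and compound 4, with no ring, although the step between these two cannot be read since both values are limits.

The compounds shown do not separate the contributions of the isopropyl group, the carbamoyl unit and the methyl link, so the change cannot be assigned to any one part of the incoming group. A primary carboxamide, a carboxylic acid or a simple amine on the same carbon would show whether the drop in this assay holds across groups with no ring or belongs to the isopropyl amide alone.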